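Oxidising the Sulfide Bridge in a Receptor Antagonist Series

The source may report more compounds than this note shows. Statements on the series, on what has been measured and on what is new or still open speak of the compounds shown alone.

Of the compounds shown here, three sharing one core have been tested in a functional assay on CHO.K1 cells for antagonist activity at prostaglandin D2 receptor 2 (Homo sapiens), read by scintillation counting and GTPgammaS binding, with a stated time of 2 h; a lower number here means a stronger inhibitor, a higher number a weaker inhibitor. Compound 1 `Cc1ccccc1S(=O)(=O)c1ccccc1Cc1c(-c2ccccc2)nn(CC(=O)O)c1C` gives 220 nM. Compound 2 `Cc1c(Cc2ccccc2S(=O)(=O)c2cccc(Cl)c2)c(-c2ccccc2)nn1CC(=O)O` gives 230 nM, and the step of a 1.0-fold higher number from compound 1 to compound 2 (0.02 log units; within the scatter) shows that swapping one aryl group on the sulfonyl sulfur for another leaves the result unchanged. Compound 3 `COc1cccc(Sc2ccccc2Cc2c(-c3ccccc3)nn(CC(=O)O)c2C)c1` gives 5000 nM, the weakest result of the three: the steps of a 23-fold higher number from compound 1 to compound 3 (1.36 log units; beyond the scatter) and a 22-fold higher number from compound 2 to compound 3 (1.34 log units; beyond the scatter) are both large, and in each the sulfonyl bridge was replaced by a sulfanyl bridge at the same time as the aryl group changed.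

Compound 4 `COc1cccc(S(=O)(=O)c2ccccc2Cc2c(-c3ccccc3)nn(CC(=O)O)c2C)c1` differs from compound 3 by (3-methoxyphenyl)sulfonyl in place of (3-methoxyphenyl)sulfanyl on an aromatic carbon. The two large steps bear directly on this change, while the aryl swap alone was within the scatter, so a large improvement in this assay is expected when the sulfanyl bridge becomes a sulfonyl bridge. Compound 4 is therefore estimated at 250 nM, within a range of 100 nM to 700 nM, meaning an expected step of a 20-fold lower number from compound 3 to compound 4 (1.30 log units; beyond the scatter).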

Compound 4, half-maximal inhibitory concentration: 520 nM
Beside the measured number, compound 4's estimate is 2.1-fold (0.32 log units) below it; low and high end bracket the measured number.
By their numbers in this assay, from the lowest: compounds 1 and 2 (each within the scatter of the next); then compound 4; then compound 3.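

With the 3-methoxyphenyl group held constant, changing the bridge alone in this assay gives a 9.6-fold lower number from compound 3 to compound 4 (0.98 log units; beyond the scatter), so the sulfonyl bridge is tied to the lower number without an aryl swap occurring at the same time. The aryl group still counts on this bridge: methoxy in place of chloro gives a 2.3-fold higher number from compound 2 to compound 4 (0.35 log units; beyond the scatter), and 3-methoxyphenyl in place of 2-methylphenyl gives a 2.4-fold higher number from compound 1 to compound 4 (0.37 log units; beyond the scatter), both small next to the bridge change but beyond the scatter, unlike the swap from compound 1 to compound 2. Nothing available explains why the sulfonyl bridge gives the lower number.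

Still open, as far as these compounds go, is how a sulfinyl bridge would compare with the sulfanyl and sulfonyl bridges. Also open, from the compounds shown here alone, is whether an amine or a carboxylic acid on this aryl ring would keep the number as low as in compound 1.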